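This account rests on a few compounds, and the source may have more. Where it says the series, first, only, none or still open, it means among the compounds named here.

Of the compounds shown here, three with the same core have been measured in a functional assay, with a stated time of 90 s; a higher number here means a weaker inhibitor, a lower number a stronger inhibitor. Compound 1 `Cc1nc2c3ccccc3ccc2c2nc3c(ccc4ccccc43)c(-c3cccc4ccccc34)c12` gives 179 ug/mL. Compound 2 `Cc1nc2c3ccccc3ccc2c2nc3c(ccc4ccccc43)c(-c3ccccc3N)c12` gives 125 ug/mL. Compound 3 `Cc1nc2c3ccccc3ccc2c2nc3c(ccc4ccccc43)c(-c3ccccc3S)c12` gives 158 ug/mL, the second highest of the three numbers, with compound 1 the nearest and compound 2 the furthest, both within the scatter. The steps among them are small: a 1.4-fold lower number from compound 1 to compound 2 (0.16 log units; within the scatter), a 1.1-fold lower number from compound 1 to compound 3 (0.05 log units; within the scatter) and a 1.3-fold higher number from compound 2 to compound 3 (0.10 log units; within the scatter). Each of these swaps the group that sits on the aromatic carbon ortho to the large core, and none moves the number beyond the scatter.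

Compound 4 `Cc1nc2c3ccccc3ccc2c2nc3c(ccc4ccccc43)c(-c3ccccc3)c12` is not yet measured. The change from compound 3 is hydrogen in place of sulfanyl on an aromatic carbon, on an aromatic carbon of a six-membered aromatic ring of carbon only. The step from compound 2 to compound 3 bears most directly, since it also exchanges the group at that carbon, and it stayed within the scatter; the steps from compound 1 point the same way. No step beyond the scatter is therefore expected in this assay , in either direction. Compound 4 is estimated at 160 ug/mL, with a range from 90 ug/mL to 280 ug/mL, which means an expected step of a 1.0-fold higher number from compound 3 to compound 4 (0.01 log units; within the scatter).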

Compound 4, half-maximal inhibitory concentration: 188 ug/mL
Compound 4: the middle estimate sits 1.2-fold (0.07 log units) below what was measured; the range from low to high includes it.
By their numbers in this assay, from the lowest: compounds 2, 3, 1 and 4 (each within the scatter of the next).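

Compound 4 has plain hydrogen where compound 3 has sulfanyl and compound 2 has amino, so it shows what these groups add to the bare phenyl. In this assay, the three comparisons give a 1.2-fold higher number from compound 3 to compound 4 (0.08 log units; within the scatter), a 1.5-fold higher number from compound 2 to compound 4 (0.18 log units; within the scatter) and, for phenyl in place of naphthalen-1-yl, a 1.1-fold higher number from compound 1 to compound 4 (0.02 log units; within the scatter), and all lie within the scatter, so neither group nor the larger naphthalen-1-yl separates from the bare phenyl at this position. Nothing available explains why the number stays so flat across these changes.

From the compounds shown here alone, whether a carboxylic acid, a methoxy group or a longer chain in place of the sulfanyl would move the number beyond the scatter remains open. Also open, going by these compounds, is whether replacing the methyl on the shared core would have a larger effect than these swaps.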